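Swapping the Amide Substituent: From Cyclohexyl to Piperazine

The source may hold more compounds than are shown below. What is called first, only, known or untested is meant among the compounds shown, and "the series" means these compounds.

Three amides on the shared core have been tested in a functional assay on the whole organism (strain Wistar) for inhibition, with Rattus norvegicus as the target, read by paw edema, with stated times of 60 min and 24 h, at a dose of 100 mg/kg by the oral route; on this read-out lower numbers stand for less inhibition and higher numbers for more inhibition at the one dose given (going by the name of the read-out). Compound 1 `COc1cc2c(cc1OC)C(CC(=O)NC(C)(C)C)CC2` gives 40%. Compound 2 `COc1cc2c(cc1OC)C(CC(=O)NC1CCCC1)CC2` gives 46.7%. Compound 3 `COc1cc2c(cc1OC)C(CC(=O)NC1CCCCC1)CC2` gives 53.3%, the highest of the three numbers, though its gap to compound 2 lies within the scatter; only its gap to compound 1 lies beyond it, namely a number 13.3 percentage points higher from compound 1 to compound 3 (beyond the scatter). The two smaller steps, a number 6.7 percentage points higher from compound 1 to compound 2 (within the scatter) and a number 6.6 percentage points higher from compound 2 to compound 3 (within the scatter), are both within the scatter. Compound 4 `COc1cc2c(cc1OC)C(CC(=O)N1CCNCC1)CC2` differs from compound 3 in one place: piperazin-1-yl in place of cyclohexylamino on a carbonyl carbon. Among the measured compounds shown here, none of the measured steps brings in a ring with hetero atoms; all three exchange one carbon-only substituent for another on the amide-type nitrogen, so no measured step bears directly on this change, and the measured steps show only that such exchanges move the read-out modestly at most. The expectation for compound 4 is therefore cautious and wide: a step of a number 13.3 percentage points lower from compound 3 to compound 4 (beyond the scatter) is expected, giving an estimated 40%, with a range from 25% to 55%.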

Compound 4, a percentage reported as inhibition, in the whole organism at one dose (the size of the read-out at that dose, not a potency): 65%
Estimate against measurement, compound 4: 25 percentage points below; the whole stated range lies below it.
By their numbers in this assay, from the lowest: compounds 1, 2 and 3 (each within the scatter of the next, the first and the last beyond it); then compound 4.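

The carbonyl carbon of the shared core accepts a ring with hetero atoms, and in this assay the change gives a gain rather than a loss (a number 11.7 percentage points higher from compound 3 to compound 4 (beyond the scatter)). The gain holds against the other two amides (a number 18.3 percentage points higher from compound 2 to compound 4 (beyond the scatter); a number 25 percentage points higher from compound 1 to compound 4 (beyond the scatter)), and all three steps lie beyond the scatter, so compound 4 gives the highest number of the series, whereas the carbon-only substituents alone left compound 2 and compound 3 within the scatter of each other. Nothing shown says what lies behind this gain.

On these data alone, it remains open whether the gain belongs to the second ring nitrogen or to a ring joined through its nitrogen; piperidin-1-yl and morpholin-4-yl on the same carbonyl carbon would help separate the two. With only one dose shown, the read-out also leaves the potency of compound 4 open.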